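The source may hold more compounds than are shown below. What is called first, only, known or untested is meant among the compounds shown, and "the series" means these compounds.

Compound 1 `COc1ccc(-c2cc(-c3ccc(S(=O)(=O)N(C)C)cc3)cnc2N)cn1`: in an in vitro ADME assay on microsomes from liver (Homo sapiens) for metabolic stability (a higher number here means that the compound lasts longer, a lower number that the compound disappears faster), compound 1 gives 0.292 h.
Compound 2 `COc1ccc(-c2cc(-c3ccc(C(F)(F)F)cc3)cnc2N)cn1`: in this assay compound 2 gives 4.75 h.
Compound 3 `COc1ccc(-c2cc(-c3ccc(-n4cncn4)cc3)cnc2N)cn1`: in this assay compound 3 gives 3.5 h.

Compound 3 stands second of the three on these numbers: its nearest neighbour is compound 2, by a 1.4-fold lower number from compound 2 to compound 3 (0.13 log units; within the scatter), and its furthest is compound 1, by a 12-fold higher number from compound 1 to compound 3 (1.08 log units; beyond the scatter). Compound 4 `COc1ccc(-c2cc(-c3ccc(C(=O)O)cc3)cnc2N)cn1` has not yet been measured. It differs from compound 3 in one place: carboxy in place of 1H-1,2,4-triazol-1-yl on an aromatic carbon. Within the data shown here, no measured step swaps exactly this pair of groups. What bears on it is that both replacements of dimethylsulfamoyl on this aromatic carbon gave large gains, a 16-fold higher number from compound 1 to compound 2 (1.21 log units; beyond the scatter) and a 12-fold higher number from compound 1 to compound 3 (1.08 log units; beyond the scatter), while the exchange between trifluoromethyl and triazolyl was small, a 1.4-fold lower number from compound 2 to compound 3 (0.13 log units; within the scatter). Nothing here shows a carboxy group, so the direction is open. Compound 4 is expected to stand close to compound 3, a 1.3-fold higher number from compound 3 to compound 4 (0.11 log units; within the scatter), a step within the scatter or a little upward. Compound 4 is therefore estimated at about 4.5 h in this assay, with a range from 1.5 h to 13 h.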

Compound 4, half-life: > 4.16 h
Compound 4 gave a limit, no number (the forecaster's own chance of this, stated with the estimate: 15%); the middle value lies beyond the limit too.
By their numbers in this assay, from the lowest: compound 1; then compounds 3 and 2 (each within the scatter of the next).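

A carboxy group on this aromatic carbon keeps the gain over dimethylsulfamoyl, an at least 14-fold higher number from compound 1 to compound 4 (1.15 log units; beyond the scatter), so the gain seen with trifluoromethyl and 1H-1,2,4-triazol-1-yl now extends to a third group, one that, unlike 1H-1,2,4-triazol-1-yl, carries a hydrogen-bond donor. Replacing 1H-1,2,4-triazol-1-yl with carboxy shows no loss, an at least 1.1-fold higher number from compound 3 to compound 4 (0.07 log units; that floor lies within the scatter), although the true size of this step remains unfixed. In this assay compound 4 gives > 4.16 h, which is a limit and not a number: the limit of > 4.16 h in this assay, at which 1 of the 4 values shown sits.

On these data alone, the step between trifluoromethyl and carboxy cannot be read, so how compound 4 stands against compound 2 stays open. Also open is whether a primary amide, a methyl ester or a nitrile on this aromatic carbon would hold the gain, and which part of dimethylsulfamoyl goes with the short half-life of compound 1, 0.292 h, since a sulfonamide with a free amino group or a methyl sulfone does not appear among the compounds shown.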